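This account rests on a few compounds, and the source may have more. Where it says the series, first, only, none or still open, it means among the compounds named here.

Compound 1 `COC(=O)/C(=C/c1ccccc1)CN1C(=O)[C@@H](OC)[C@H]1c1cccc(Cl)c1`: "not toxic" (no number reported)
Compound 2 `COC(=O)/C(=C/c1ccccc1)CN1C(=O)[C@@H](OC)[C@H]1c1cccc(F)c1`: 38500 nM

In an ADME assay on cells (Epithelial cell, Homo sapiens) for antiproliferative activity, read by MTT assay, with a stated time of 48 h (a higher number here means a weaker inhibitor, a lower number a stronger inhibitor), compound 2 gives 38500 nM. Going by the values given here, this is the only number available so far, so it cannot yet be ranked against any other measured value. Compound 1 is recorded as "not toxic" (no number reported), with no number to compare.

The next compound to be tested is compound 3 `COC(=O)/C(=C/c1ccccc1)CN1C(=O)[C@@H](OC)[C@H]1c1ccccc1`, which has the same core as compound 2. The change is hydrogen in place of fluoro on an aromatic carbon. In plain terms, hydrogen takes the place of fluoro on an aromatic carbon, so 3-fluorophenyl becomes phenyl.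

Among the compounds with values here, no measured pair in this set shows what this swap does, so any expectation is tentative. Compound 2, at 38500 nM, offers the only numerical anchor. The expected result is a 1.0-fold higher number from compound 2 to compound 3 (0.02 log units; within the scatter), which is estimated to lie within the usual scatter, with no clear direction. Compound 3 could also end up without a number, as compound 1 did with "not toxic" (no number reported). For compound 3, the estimated value is 40000 nM, with an expected range from 15000 nM to 100000 nM.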

Compound 3, half-maximal inhibitory concentration: "not toxic" (no number reported)
For compound 3 the study gives words and no number, so the estimate cannot be set against anything.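

Going by these compounds alone, compound 3 is recorded as "not toxic" (no number reported) and carries no number, so no step from compound 2 to compound 3 can be read. From the compounds shown here alone, what the change from 3-fluorophenyl to phenyl does to the read-out stays open, and so does how compound 1 and compound 3 rank against compound 2. Nothing measured here offers an explanation for this result.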